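Aryl Amide in Place of Alkyl Amide on the Shared Core

This account rests on a few compounds, and the source may have more. Where it says the series, first, only, none or still open, it means among the compounds named here.

Compound 2 `C=CC1=C(C(=O)NCC(C)C)C(c2ccc(F)cc2)OC1` carries an isobutyl group on its amide nitrogen. In a functional assay on SW480 cells (Homo sapiens) for cytotoxicity, read by MTT assay, with a stated time of 24 h (a higher number here means a weaker inhibitor, a lower number a stronger inhibitor), compound 2 gives > 100000 nM, which is a limit of the assay rather than a number. Among the compounds with values here, its only measured neighbour is compound 1 `C=CC1=C(C(=O)NCc2ccc(C)cc2)C(c2ccc(F)cc2)OC1`. In this assay compound 1 gives > 100000 nM, again a limit. The change from compound 1 to compound 2, a step that the two limits leave unreadable from compound 1 to compound 2, therefore cannot be sized. Compound 3 `C=CC1=C(C(=O)Nc2ccc(C)cc2)C(c2ccc(F)cc2)OC1` is the next move: 4-methylphenyl in place of isobutyl on an amide-type nitrogen. Within the data shown here, no measured step can guide this change, since the limit of > 100000 nM in this assay, at which 2 of the 2 values shown sit, is all that the two neighbours show. The step that the limit leaves unreadable from compound 2 to compound 3 is expected to stay within the scatter, with no readable direction. Compound 3 is expected to give 150000 nM, between 40000 nM and 1000000 nM, and most likely the assay will again report only a limit.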

Compound 3, half-maximal inhibitory concentration: > 100000 nM
Compound 3: only a limit was reported; the forecaster's own chance of this, stated with the estimate: 85%; the middle value lies beyond the limit too.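

In this assay compound 3 gives > 100000 nM, again a limit of the assay and not a number. Within the data shown here, no step among compound 1, compound 2 and compound 3 can be read. Whether any change on the amide nitrogen alters the cytotoxicity stays open, as all three compounds share one reading: the limit of > 100000 nM in this assay, at which 3 of the 3 values shown sit.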